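The source may report more compounds than this note shows. Statements on the series, on what has been measured and on what is new or still open speak of the compounds shown alone.

The three measured compounds share one core and differ only in the aryl group on the carbon with a double bond to nitrogen. Compound 1 `COc1ccc(OC)c(/C=N/NC(=O)Nc2ccc(Oc3ccnc(-c4nncn4CCN(C)C)c3)c(F)c2)c1` gives 6400 nM in a functional assay on U-87MG ATCC cells (Homo sapiens) for cytotoxicity, read by MTT assay, with a stated time of 72 h; on this read-out higher numbers stand for weaker inhibition and lower numbers for stronger inhibition; compound 2 `CN(C)CCn1cnnc1-c1cc(Oc2ccc(NC(=O)N/N=C/c3ccccc3)cc2F)ccn1` gives 2250 nM; compound 3 `COc1cc(/C=N/NC(=O)Nc2ccc(Oc3ccnc(-c4nncn4CCN(C)C)c3)c(F)c2)cc(OC)c1OC` gives 22500 nM. Compound 3 thus shows the highest number of the three, and the steps run a 3.5-fold higher number from compound 1 to compound 3 (0.55 log units; beyond the scatter) and a 10-fold higher number from compound 2 to compound 3 (1.00 log units; beyond the scatter), while a 2.8-fold lower number from compound 1 to compound 2 (0.45 log units; beyond the scatter).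

Compound 4 `CN(C)CCn1cnnc1-c1cc(Oc2ccc(NC(=O)N/N=C/c3cccc(Cl)c3Cl)cc2F)ccn1` is obtained by the change (2,3-dichlorophenyl in place of 3,4,5-trimethoxyphenyl on a carbon with a double bond to nitrogen). Within the data shown here, the steps that bear on it are those that strip methoxy groups from this aryl ring, above all a 10-fold higher number from compound 2 to compound 3 (1.00 log units; beyond the scatter), which shows the unsubstituted phenyl giving a much lower number than the trimethoxy ring. A dichlorophenyl carries no methoxy group, so a lower number than compound 3, of a size near that step, is expected for compound 4 in this assay, namely a 9.0-fold lower number from compound 3 to compound 4 (0.95 log units; beyond the scatter). Compound 4 is therefore estimated at 2500 nM, within a range of 800 nM to 8000 nM.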

Compound 4, half-maximal inhibitory concentration: 13200 nM
Compound 4: the middle estimate sits 5.3-fold (0.72 log units) below what was measured; the whole stated range lies below it.
By their numbers in this assay, from the lowest: compound 2; then compound 1; then compounds 4 and 3 (each within the scatter of the next).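

In this assay, the absence of methoxy groups on the aryl ring is not enough to reach the number of the plain phenyl: the 2,3-dichlorophenyl group stands clearly apart from it (a 5.9-fold higher number from compound 2 to compound 4 (0.77 log units; beyond the scatter)) and also from the 2,5-dimethoxyphenyl group (a 2.1-fold higher number from compound 1 to compound 4 (0.31 log units; beyond the scatter)). It cannot be told apart from the 3,4,5-trimethoxyphenyl group (a 1.7-fold lower number from compound 3 to compound 4 (0.23 log units; within the scatter)), so all three substituted rings shown, with chlorine or with methoxy groups, give higher numbers than the unsubstituted phenyl of compound 2. Nothing available explains why the dichlorophenyl ring behaves this way.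

The compounds shown leave open whether a ring with a single chlorine, a single methoxy group, an amine or a carboxylic acid on this carbon with a double bond to nitrogen would stay nearer compound 2. They also leave open whether the result follows from the chlorines themselves or from where they sit on the ring.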